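The source may hold more compounds than are shown below. What is called first, only, known or untested is meant among the compounds shown, and "the series" means these compounds.

Measured compounds in a functional assay on HepG2 cells (Homo sapiens) for cytotoxicity, read by MTT assay, with a stated time of 72 h; a higher number here means a weaker inhibitor, a lower number a stronger inhibitor:

Compound 1 `Cc1cc(=O)n(-c2ccc(Br)cc2F)nc1C(=O)Nc1ccc(Oc2ncnc3ccsc23)cc1` gives 10600 nM.
Compound 2 `Cc1cc(=O)n(-c2ccccc2OC(F)(F)F)nc1C(=O)Nc1ccc(Oc2ncnc3ccsc23)cc1` gives 25000 nM.
Compound 3 `Cc1cc(=O)n(-c2ccc(Br)cc2F)nc1C(=O)Nc1ccc(Oc2ncnc3ccsc23)c(F)c1` gives 3350 nM.

The three measured compounds share one scaffold and differ at two places. Between compound 1 and compound 2 the change is 2-(trifluoromethoxy)phenyl in place of 4-bromo-2-fluorophenyl on an aromatic nitrogen, and this change produced a step of a 2.4-fold higher number from compound 1 to compound 2 (0.37 log units; beyond the scatter). Between compound 1 and compound 3 the change is fluoro in place of hydrogen on an aromatic carbon, which produced a step of a 3.2-fold lower number from compound 1 to compound 3 (0.50 log units; beyond the scatter). Compound 3 therefore has the lowest number of the three, and its steps to both compound 1 and compound 2 lie beyond the scatter, so it is the strongest inhibitor of the set in this assay.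

Compound 4 `Cc1cc(=O)n(-c2ccccc2OC(F)(F)F)nc1C(=O)Nc1ccc(Oc2ncnc3ccsc23)c(F)c1` has not yet been measured. Within the data shown here, it differs from compound 3 by 2-(trifluoromethoxy)phenyl in place of 4-bromo-2-fluorophenyl on an aromatic nitrogen, which is the same change as the one from compound 1 to compound 2, made on the core of compound 3 rather than the core of compound 1. The two cores differ by fluoro in place of hydrogen on an aromatic carbon. The change from compound 1 to compound 2 occurs twice among these compounds, once measured and once not.

Among the measured compounds shown here, the step from compound 3 to compound 4 in this assay is expected to be a 2.4-fold higher number from compound 3 to compound 4 (0.38 log units; beyond the scatter), because the same change gave a 2.4-fold higher number from compound 1 to compound 2 (0.37 log units; beyond the scatter) in the only pair where it has been measured. On that basis compound 4 is estimated to give 8000 nM. The range for compound 4 is estimated to run from 3500 nM to 20000 nM.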

Compound 4, half-maximal inhibitory concentration: 15700 nM
Compound 4: middle estimate off by 2.0-fold (0.29 log units), on the low side; low and high end bracket the measured number.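

In this assay, placing 2-(trifluoromethoxy)phenyl in place of 4-bromo-2-fluorophenyl on the fluoro-bearing core gave a 4.7-fold higher number from compound 3 to compound 4 (0.67 log units; beyond the scatter), in the same direction as the step on the core without that fluoro, and the two steps do not differ beyond what scatter allows: the same change on two cores in this assay, a 2.4-fold higher number (0.37 log units; beyond the scatter) from compound 1 to compound 2 and a 4.7-fold higher number (0.67 log units; beyond the scatter) from compound 3 to compound 4, 2.0-fold (0.30 log units) apart, within the scatter of two such steps. Read across the other way, fluoro in place of hydrogen on the aromatic carbon gave a 1.6-fold lower number from compound 2 to compound 4 (0.20 log units; within the scatter), a step that on its own cannot be told from scatter, yet it too cannot be separated from the earlier step with the other aryl group: the same change on two cores in this assay, a 3.2-fold lower number (0.50 log units; beyond the scatter) from compound 1 to compound 3 and a 1.6-fold lower number (0.20 log units; within the scatter) from compound 2 to compound 4, 2.0-fold (0.30 log units) apart, within the scatter of two such steps. Within these four compounds, then, neither change shows any measurable dependence on the core that carries it, but each comparison rests on only two steps, so this does not show that the steps are equal, nor that they would carry over to any further core.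

The compounds shown leave open whether other groups on the aromatic nitrogen, such as an unsubstituted phenyl or a pyridyl, would follow the same steps. They also leave open whether chloro or methyl in place of the added fluoro would behave as fluoro does on either core.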